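Phenyl for Fluoro on the Amide Aryl of Compound 3

A few compounds are considered here, and "the series" means these few. Any claim that something is new, unique, unknown or untested is made for them only; others in the source may bear on it.

Compound 1, `O=C(COc1ccc2c(=O)cc(-c3ccccc3)oc2c1)Nc1ccc2ccccc2c1`: in a functional assay on NPC-TW01 cells (Homo sapiens) for antiproliferative activity, read by MTT assay, with a stated time of 72 h (a higher number here means a weaker inhibitor of growth, a lower number a stronger inhibitor of growth), compound 1 gives > 10000 nM, which is a limit of the assay and not a number.
Compound 2, `O=C(COc1c(-c2ccccc2)oc2ccccc2c1=O)Nc1ccc(-c2ccccc2)cc1`: in this assay compound 2 gives > 10000 nM, also a limit.
Compound 3, `O=C(COc1ccc2c(=O)cc(-c3ccccc3)oc2c1)Nc1ccc(F)cc1`: in this assay compound 3 gives > 10000 nM, again a limit.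

Compound 3 therefore stands where every measured compound stands: the limit of > 10000 nM in this assay, at which 3 of the 3 values shown sit. For the measured compounds named here, the one measured step, a step that the two limits leave unreadable from compound 1 to compound 3, cannot be read in size or direction, since both of its ends are limits. Compound 4, `O=C(COc1ccc2c(=O)cc(-c3ccccc3)oc2c1)Nc1ccc(-c2ccccc2)cc1`, differs from compound 3 by phenyl in place of fluoro on an aromatic carbon. Compound 2 carries the same amide aryl group as compound 4 on a core arranged differently from the shared core of compounds 1, 3 and 4, and its value is a limit as well. Going by the values given here, no measured step gives a direction for the change from compound 3 to compound 4, so no movement beyond the scatter is expected in this assay, and the step that the limit leaves unreadable from compound 3 to compound 4 is an estimate of no real change. Compound 4 is expected to give about 15000 nM in this assay, in the range 5000 nM to 50000 nM, most likely again reported only as a limit.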

Compound 4, concentration for 50% growth inhibition: 1610 nM
For compound 4 the middle estimate is 9.3-fold (0.97 log units) above the measured one; measured number below the stated range.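

On the shared core, the aromatic carbon para to a large group is a place where a change can move growth inhibition: phenyl in place of fluoro there gives an at least 6.2-fold lower number from compound 3 to compound 4 (0.79 log units; beyond the scatter) in this assay on this core. Compound 1, with naphthalen-2-yl on the amide nitrogen of the same core, gives > 10000 nM as a limit of the assay, so a large all-carbon aromatic group on that nitrogen is not enough by itself. For the compounds shown here, compound 4 is now the only compound with a real number: the limit of > 10000 nM in this assay, at which 3 of the 4 values shown sit.

From the compounds shown here alone, the full size of the step stays open, as its starting point is a limit and not a number. Also open, going by these compounds, is how an amine, a carboxylic acid or a longer chain on that same aromatic carbon, or on the added phenyl ring, would compare with phenyl.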